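One enantiomer of compound 2 in the atrium assay

This account rests on a few compounds, and the source may have more. Where it says the series, first, only, none or still open, it means among the compounds named here.

Compound 1 `Cc1nc(N)sc1CCCNC(=N)NC(=O)C[C@H](C)C1CCCCC1`: 78%
Compound 2 `Cc1nc(N)sc1CCCNC(=N)NC(=O)CC(C)c1ccccc1`: 89%

Both values come from a functional assay on cardiac atrium for agonist activity at histamine H2 receptor (Cavia porcellus); on this read-out higher numbers stand for larger maximal responses and lower numbers for smaller maximal responses. Of the two numbers, compound 2 stands highest; its nearest neighbour is compound 1, and the step between them is a number 11 percentage points higher from compound 1 to compound 2 (beyond the scatter), which replaces 1-cyclohexylethyl with 1-phenylethyl on a saturated chain carbon bound to a carbonyl carbon.

Compound 3 `Cc1nc(N)sc1CCCNC(=N)NC(=O)C[C@H](C)c1ccccc1` has not yet been measured in this assay. It differs from compound 2 only in this way: the two compounds have the same atoms and bonds; at least one stereo element is drawn with a configuration in one of them and without one in the other: 1 of 2 stereo elements differ; a stereocentre at a saturated chain carbon is drawn without a configuration in compound 2 and S in compound 3. Compound 2 is thus the material with the stereocentre undefined, and compound 3 one defined form of it.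

Going by the values given here, no measured step bears on this change. Among the compounds with values here, the only step known, that from compound 1 to compound 2, alters the group on the chain carbon, not its configuration, so it gives no guidance on what a single configuration does. Given that compound 2 already reaches a high maximal response, compound 3 is expected to stay near it, with a step of no change at the digits printed from compound 2 to compound 3 (within the scatter) that is not expected to go beyond the scatter. The estimate for compound 3 is therefore 89%, within a range from 75% to 100%.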

Compound 3, largest response reached (Emax), in percent of the reference or control that the assay uses: 87%
Estimate against measurement, compound 3: 2 percentage points above, and the stated range covers the measured number.
By their numbers in this assay, from the lowest: compounds 1, 3 and 2 (each within the scatter of the next, the first and the last beyond it).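

Setting the stereocentre at the saturated chain carbon to S changes little in this assay (a number 2 percentage points lower from compound 2 to compound 3 (within the scatter)), so the defined form keeps the high maximal response of the material with the stereocentre undefined. Compound 3 also gives a second reading of phenyl in place of cyclohexyl (a number 9 percentage points higher from compound 1 to compound 3 (within the scatter)), which lies within the scatter, whereas the earlier reading of that ring change (a number 11 percentage points higher from compound 1 to compound 2 (beyond the scatter)) lay beyond it, so the earlier gap between the two rings does not hold up once the phenyl compound is a defined form. What separates these two readings is a single difference in how the phenyl compounds are drawn: the fact that one of compounds 2 and 3 is drawn with a defined configuration and the other without, at the place where they differ.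

The maximal response of the opposite configuration at this carbon stays open, so the compounds shown cannot say whether the response depends on configuration at all. Also open, going by these compounds, is how far the response tolerates other groups on this carbon, such as an ethyl in place of the methyl or a cyclopentyl in place of the phenyl, and the read-out here speaks only to the largest response reached, not to the concentration needed to reach it.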